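A few compounds are considered here, and "the series" means these few. Any claim that something is new, unique, unknown or untested is made for them only; others in the source may bear on it.

In an ADME assay on L6 cells (Rattus norvegicus) for cytotoxicity, read by resazurin assay, with a stated time of 72 h (on this read-out higher numbers stand for weaker inhibition and lower numbers for stronger inhibition), compound 1 `OC(c1ccc(Cl)cc1)(c1cccnc1)c1ccccc1F` gives > 100000 nM, which is a limit and not a number. Among the compounds with values here, compound 2 `CC(C)Oc1ccccc1C(O)(c1ccc(Cl)cc1)c1cccnc1`, at 48300 nM, holds the only true number so far. Compound 3 `OC(c1ccc(Cl)cc1)(c1cccnc1)c1ccccc1C(F)(F)F` has trifluoromethyl in place of isopropoxy on an aromatic carbon, ortho to a large group (trifluoromethyl in place of isopropoxy on an aromatic carbon). Within the data shown here, the one measured step that bears on this is an at least 2.0-fold lower number from compound 1 to compound 2 (0.31 log units; beyond the scatter), where isopropoxy replaced fluoro, and its size is only a bound, as the limit of > 100000 nM in this assay, at which 1 of the 2 values shown sits, shows. Losing isopropoxy should therefore raise the number modestly. The expected step is a 1.7-fold higher number from compound 2 to compound 3 (0.22 log units; within the scatter). Compound 3 is estimated at 80000 nM, within an expected range of 40000 nM to 150000 nM.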

Compound 3, half-maximal inhibitory concentration: 59300 nM
Beside the measured number, compound 3's estimate is 1.3-fold (0.13 log units) above it; measured number inside the range.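

In this assay, trifluoromethyl in place of isopropoxy gives a 1.2-fold higher number from compound 2 to compound 3 (0.09 log units; within the scatter), so these two groups cannot be told apart at this position, although only isopropoxy carries a hydrogen-bond acceptor. Trifluoromethyl in place of fluoro gives an at least 1.6-fold lower number from compound 1 to compound 3 (0.22 log units; that floor lies within the scatter), so, unlike the earlier step from fluoro, this step does not by itself show a real change, and its true size stays open: the limit of > 100000 nM in this assay, at which 1 of the 3 values shown sits.

As far as these compounds go, whether an amine, a carboxylic acid or a longer chain at this position would move the number beyond the scatter remains open.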